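Swapping a hydroxyalkyl for a fluorophenyl on the ring nitrogen

This account rests on a few compounds, and the source may have more. Where it says the series, first, only, none or still open, it means among the compounds named here.

Measured so far in an ADME assay on microsomes from liver (Mus musculus) for metabolic stability, read by LC-MS, using NADPH, with a stated time of 60 min, tested at 1 uM, in the presence of a further agent that is not named here; on this read-out lower numbers stand for slow clearance and higher numbers for fast clearance:
- compound 1 `Clc1ccc2nc(-c3ccccn3)c(Nc3ccc4c(c3)OCCO4)n2c1`: > 1000 uL/min, a limit of the assay
- compound 2 `CC(C)(O)CNc1c(-c2ccccn2)nc2ccccn12`: 171 uL/min
- compound 3 `CN(c1ccc(F)cc1)c1c(-c2ccccn2)nc2ccccn12`: > 1000 uL/min, a limit of the assay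

For the measured compounds named here, compound 2 is the only member of this trio with an actual number; the other two sit at the limit of > 1000 uL/min in this assay, at which 2 of the 3 values shown sit. Compound 4 `Fc1cccc(Nc2c(-c3ccccn3)nc3ccccn23)c1` has not yet been run. It differs from compound 2 in one place: 3-fluorophenyl in place of 2-hydroxy-2-methylpropyl on a nitrogen on an aromatic ring. Going by the values given here, with no measured pair of this kind to lean on, the expectation for compound 4 rests on compound 3, which also carries a fluorine-bearing phenyl ring and gives > 1000 uL/min. A large rise in clearance from compound 2 to compound 4 is expected, a 5.3-fold higher number from compound 2 to compound 4 (0.72 log units; beyond the scatter), well beyond the scatter. Compound 4 is estimated at 900 uL/min, between 350 uL/min and 2500 uL/min.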

Compound 4, intrinsic clearance in a liver preparation (reported as CLH), per the amount of preparation that the assay uses: 242 uL/min
Beside the measured number, compound 4's estimate is 3.7-fold (0.57 log units) above it; the whole stated range lies above it.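

In this assay, the step of a 1.4-fold higher number from compound 2 to compound 4 (0.15 log units; within the scatter) shows that this nitrogen can carry the 3-fluorophenyl ring in place of the 2-hydroxy-2-methylpropyl chain with no measurable difference in clearance. For the compounds shown here, compound 4 thus gives the first real number for a phenyl ring on this nitrogen, whereas compound 1 and compound 3 each give only a limit of the assay. Nothing given here explains this result.

Still open, on these data alone, is how an amine, a carboxylic acid or a longer chain on this nitrogen would behave.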